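Dipropylamino in place of a urea on the shared core

The source may hold more compounds than are shown below. What is called first, only, known or untested is meant among the compounds shown, and "the series" means these compounds.

Measured compounds:
compound 1 `Cc1ccn2c(N)c(C)nc2c1OCc1ccccc1` with 55%
compound 2 `CNC(=O)Nc1c(C)nc2c(OCc3ccccc3)cccn12` with 27%

Of the compounds shown here, two have been tested in a functional assay on the whole organism with Canis familiaris (Canis lupus familiaris) as the target, at a dose of 5 mg/kg by the intravenous route; a higher number here means a stronger effect of the compound at the dose given, a lower number a weaker effect. Compound 1 `Cc1ccn2c(N)c(C)nc2c1OCc1ccccc1` gives 55% in this assay. Compound 2 `CNC(=O)Nc1c(C)nc2c(OCc3ccccc3)cccn12` gives 27% in this assay, the lowest of the two numbers, and the gap from compound 2 to compound 1 lies beyond the usual scatter of repeated measurements. Within the data shown here, no step between compounds that differ in a single place has been measured, so nothing is yet known about how a change at one position moves the number.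

Compound 3 `CCCN(CCC)c1c(C)nc2c(OCc3ccccc3)cccn12` is the next compound to be measured. It differs from compound 2 in one place: dipropylamino in place of (methylcarbamoyl)amino on an aromatic carbon. Compound 1, which carries an unsubstituted amino group at that same position, stands well above compound 2, and on that basis the account expects a step upward from compound 2 to compound 3 of a number 18 percentage points higher from compound 2 to compound 3 (beyond the scatter) in this assay, beyond the scatter. Compound 3 is accordingly estimated at 45%, with a range from 20% to 70%.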

Compound 3, a percentage reported as inhibition, in the whole organism at one dose (the size of the read-out at that dose, not a potency): 0%
Estimate against measurement, compound 3: 45 percentage points above; measured number outside the range, below it.
By their numbers in this assay, from the lowest: compound 3; then compound 2; then compound 1.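

Among these compounds, putting dipropylamino in place of (methylcarbamoyl)amino on this aromatic carbon gives a number 27 percentage points lower from compound 2 to compound 3 (beyond the scatter) in this assay, the first step that isolates a change at a single place. It shows that the group at this position alone can move the read-out, and that with dipropylamino there, compound 3 gives 0% at the dose tested. The exchange removes both hydrogen-bond donors of the urea and brings in more carbon at the same time, and nothing available explains why the number falls.

This one step cannot separate the loss of the urea from the arrival of the two propyl chains, and a dimethylamino group, a single propylamino group or an acetylamino group on the same carbon would each bear on that question. On these data alone, since each number comes from one dose, it also remains open whether compound 3 would show any effect in this assay at a higher dose.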